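The compounds below may be only part of what the source reports. "The series", "measured", "known", "first", "only" and "open" are said of these compounds alone.

Compound 1 `Cc1ccc(N2CCN(Cn3nc(-c4ccc5c(c4)OCCO5)oc3=S)CC2)c(C)c1`: in a functional assay on HeLa cells (Homo sapiens) for antiproliferative activity, read by MTT assay, with a stated time of 48 h (on this read-out higher numbers stand for weaker inhibition and lower numbers for stronger inhibition), compound 1 gives only a limit of the assay, > 50000 nM.
Compound 2 `S=c1oc(-c2ccc3c(c2)OCCO3)nn1CN1CCN(c2ccc(Cl)cc2)CC1`: compound 2 also gives only a limit, > 50000 nM.
Compound 3 `S=c1oc(-c2ccc3c(c2)OCCO3)nn1CN1CCN(c2cccc(Cl)c2)CC1`: compound 3 gives 47200 nM.

Among the compounds with values here, compound 3 is the one member of this small set with an actual number in this assay; the other two sit at the limit of > 50000 nM in this assay, at which 2 of the 3 values shown sit. The two steps that lead to it, an at least 1.0-fold lower number from compound 1 to compound 3 (0.02 log units; that floor lies within the scatter) and an at least 1.0-fold lower number from compound 2 to compound 3 (0.02 log units; that floor lies within the scatter), are floors only and lie within the scatter, so compound 3 is not separated from compounds 1 and 2 beyond it. The remaining pair, a step that the two limits leave unreadable from compound 1 to compound 2, cannot be read at all.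

Compound 4 `S=c1oc(-c2ccc3c(c2)OCCO3)nn1CN1CCN(c2ccccc2)CC1` differs from compound 3 by hydrogen in place of chloro on an aromatic carbon. Within the data shown here, no measured step removes a substituent from this ring; the steps that do touch it, from compound 1 to compound 3 and from compound 2 to compound 3, exchange one aryl group for another and show nothing beyond the scatter. On that basis no step beyond the scatter is expected in this assay, and a value at or near the limit is thought likely for compound 4, that is a 1.2-fold higher number from compound 3 to compound 4 (0.07 log units; within the scatter). Compound 4 is therefore estimated at 55000 nM, within a range from 25000 nM to 120000 nM.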

Compound 4, half-maximal inhibitory concentration: > 50000 nM
Compound 4: a limit, no number; the forecaster's own chance of this, stated with the estimate: 60%; the middle value does not contradict the limit.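

For the first time, the chloro itself is taken off this aromatic carbon rather than one aryl group being exchanged for another, and in this assay hydrogen in its place gives an at least 1.0-fold higher number from compound 3 to compound 4 (0.02 log units; that floor lies within the scatter), so the chloro of compound 3 is not shown to matter beyond the scatter. That step is only a floor, since compound 4 gives > 50000 nM, which is a limit of the assay and not a number; the steps to compound 4 from compound 1 and from compound 2 join two limits and cannot be read. The bare phenyl group thus joins the 2,4-dimethylphenyl and 4-chlorophenyl groups at the edge of the measurable range, and compound 3 remains the only member with an actual number, while the set as a whole sits almost entirely at that edge: the limit of > 50000 nM in this assay, at which 3 of the 4 values shown sit.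

Going by these compounds, how far compound 4 and the other compounds at the limit lie from compound 3 remains open, as the floor gives no upper bound on the step. Also open, on these data alone, is whether a methoxy group, an amine or a carboxylic acid on this aromatic carbon would give a readable number in this assay.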